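Geometric isomer of a dienyl glycoside phenol

A few compounds are considered here, and "the series" means these few. Any claim that something is new, unique, unknown or untested is made for them only; others in the source may bear on it.

Measured so far:
compound 1 `C/C=C/C=C/CCc1cc(O)c([C@@H]2O[C@H](CO)[C@@H](O)[C@H](O)[C@H]2O)c(O)c1C(=O)OC` — > 40000 nM
compound 2 `CCC/C=C/C=C\CCc1cc(O)c([C@@H]2O[C@H](CO)[C@@H](O)[C@H](O)[C@H]2O)c(O)c1C(=O)OC` — > 40000 nM
compound 3 `CCC/C=C/C=C/CCc1cc(O)c([C@@H]2O[C@H](CO)[C@@H](O)[C@H](O)[C@H]2O)c(O)c1` — > 40000 nM

In a functional assay on RAW264.7 cells (Mus musculus) for inhibition, read by Griess assay, with stated times of 2 h and 12 h (a higher number here means a weaker inhibitor, a lower number a stronger inhibitor), compound 1 gives > 40000 nM, which is a limit of the assay. Compound 2 gives > 40000 nM, also a limit. Compound 3 gives > 40000 nM, again a limit. Within the data shown here, the only measured step, a step that the two limits leave unreadable from compound 1 to compound 2, has no readable size. Compound 3 therefore stands at the limit shared by every value shown (the limit of > 40000 nM in this assay, at which 3 of the 3 values shown sit).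

Compound 4 `CCC/C=C/C=C\CCc1cc(O)c([C@@H]2O[C@H](CO)[C@@H](O)[C@H](O)[C@H]2O)c(O)c1` differs from compound 3 thus: the two compounds have the same atoms and bonds and differ only in configuration as drawn: 1 of 7 stereo elements differ; a double bond is drawn E in compound 3 and Z in compound 4. Among the measured compounds shown here, no measured step bears on a change of double-bond geometry, and the three limits give no direction to work from. The step expected here, a step that the limit leaves unreadable from compound 3 to compound 4, is one within the scatter, most likely ending again at the limit. Compound 4 is estimated at 60000 nM, in a range from 30000 nM to 150000 nM.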

Compound 4, half-maximal inhibitory concentration: > 40000 nM
Compound 4: only a limit was reported (the forecaster's own chance of this, stated with the estimate: 85%); the middle value is on the limit's open side.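

No new step can be read: compound 2, compound 3 and compound 4 all sit at a limit of the assay. Left open is whether double-bond geometry or the methoxycarbonyl group affects inhibition at all.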